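A few compounds are considered here, and "the series" means these few. Any claim that something is new, unique, unknown or untested is made for them only; others in the source may bear on it.

Measured in an ADME assay on NIH3T3 cells (Mus musculus) for inhibition, read by MTT assay, with a stated time of 48 h; a lower number here means a stronger inhibitor, a higher number a weaker inhibitor:
Compound 1 `CCc1ccc(-c2nc3ccccn3c2Sc2ccccc2)cc1`: > 100000 nM
Compound 2 `c1ccc(Sc2c(-c3ccccc3)nc3ccc(-c4ccccc4)cn23)cc1`: > 100000 nM
Compound 3 `CS(=O)(=O)c1ccc(-c2nc3ccccn3c2Sc2cccc3ccccc23)cc1`: 86400 nM

Compound 1 gives > 100000 nM, which is a limit of the assay and not a number. Compound 2 gives > 100000 nM, which is also a limit. Compound 1 thus stands at the limit of > 100000 nM in this assay, at which 2 of the 3 values shown sit. Going by the values given here, compound 3 gives the only true number in the set, 86400 nM.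

Compound 4 `c1ccc(Sc2c(-c3cccs3)nc3ccccn23)cc1` keeps the shared core and the phenylsulfanyl group of compound 1, but carries thiophen-2-yl in place of 4-ethylphenyl on an aromatic carbon. Among the compounds with values here, no step between measured compounds shows what such an exchange does. Within the data shown here, compound 3, at 86400 nM, offers the only numerical guide, so no step beyond the scatter is expected in this assay. In this assay compound 4 may well be reported only as a limit.

The estimated value for compound 4 is 100000 nM, with an expected range from 50000 nM to 200000 nM. The expected step is a number no higher from compound 1 to compound 4 (the limit leaves the size open).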

Compound 4, half-maximal inhibitory concentration: > 100000 nM
Compound 4: only a limit was reported; the forecaster's own chance of this, stated with the estimate: 65%; the middle value sits exactly at the limit.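

In this assay compound 4 gives > 100000 nM, which is a limit and not a number. Compound 1 also stands at a limit, so the step between compound 1 and compound 4 cannot be read. The compounds shown leave open whether exchanging 4-ethylphenyl for thiophen-2-yl changes inhibition at all.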